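Chloro for Fluoro on a Nitrophenyl Arm

The compounds below may be only part of what the source reports. "The series", "measured", "known", "first", "only" and "open" are said of these compounds alone.

Compound 1 `O=C(/C(=C\c1ccc(F)c([N+](=O)[O-])c1)S(=O)(=O)c1ccc(Br)cc1)c1ccc(Br)cc1` and compound 2 `O=C(/C(=C\c1ccc(Cl)c([N+](=O)[O-])c1)S(=O)(=O)c1ccc(Br)cc1)c1ccc(Br)cc1` share one core, while compound 3 `O=C(O)c1ccc(C(=O)/C(=C\c2ccc(F)c([N+](=O)[O-])c2)SCc2ccc(C(F)(F)F)cc2)cc1` is built on another; the difference between the two cores is not broken down here. In a functional assay on DU-145 cells (Homo sapiens) for inhibition, read by trypan blue exclusion, with a stated time of 96 h (a lower number here means a stronger inhibitor of growth, a higher number a weaker inhibitor of growth), compound 1 gives 25000 nM, and compound 2 gives 10000 nM. The change between them, (chloro in place of fluoro on an aromatic carbon), brought a 2.5-fold lower number from compound 1 to compound 2 (0.40 log units; beyond the scatter). Compound 3 gives 1000 nM in this assay, the lowest of the three measured numbers. Compound 4 `O=C(O)c1ccc(C(=O)/C(=C\c2ccc(Cl)c([N+](=O)[O-])c2)SCc2ccc(C(F)(F)F)cc2)cc1` carries the same kind of change relative to compound 3, (chloro in place of fluoro on an aromatic carbon), at a place described in the same words. Within the data shown here, since the single earlier instance of this change, a 2.5-fold lower number from compound 1 to compound 2 (0.40 log units; beyond the scatter), was modest yet beyond the scatter, compound 4 is expected to show a comparable step, a 2.0-fold lower number from compound 3 to compound 4 (0.30 log units; within the scatter). The value of compound 4 in this assay is estimated at 500 nM, most likely between 200 nM and 1500 nM.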

Compound 4, concentration for 50% growth inhibition: 1000 nM
Estimate against measurement, compound 4: 2.0-fold (0.30 log units) below; measured number inside the range.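

In this assay, chloro in place of fluoro, the change from 4-fluoro-3-nitrophenyl to 4-chloro-3-nitrophenyl, gave no change at the digits printed from compound 3 to compound 4 (within the scatter), so the lower number seen with the core of compound 1 did not recur with the core of compound 3. Even so, the two steps cannot be told apart: the same change on two cores in this assay, a 2.5-fold lower number (0.40 log units; beyond the scatter) from compound 1 to compound 2 and no change at the digits printed (within the scatter) from compound 3 to compound 4, 2.5-fold (0.40 log units) apart, within the scatter of two such steps. With one pair on each core, the data neither show that the core alters the effect of the change nor establish that the effect carries over unaltered.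

The compounds shown leave open how a methoxy group in place of the halogen would behave on either core. They also leave open whether the same holds with an amine in place of the nitro group.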